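A few compounds are considered here, and "the series" means these few. Any claim that something is new, unique, unknown or untested is made for them only; others in the source may bear on it.

Measured compounds:
compound 1, `COc1cc(C(=O)c2cn(-c3ccccc3Cl)cc2-c2ccccc2)cc(OC)c1OC`: 1800 nM
compound 2, `COc1cc(C(=O)c2cn(-c3ccccc3[N+](=O)[O-])cc2-c2ccccc2)cc(OC)c1OC`: 5000 nM
compound 3, `COc1cc(C(=O)c2cn(-c3cccc(N)c3)cc2-c2ccccc2Cl)cc(OC)c1OC`: 40 nM

All three were run in a functional assay on MCF7 cells (Homo sapiens) for cytotoxicity, read by MTT assay, with a stated time of 96 h; on this read-out lower numbers stand for stronger inhibition and higher numbers for weaker inhibition. Compound 1 and compound 2 differ in one place only, (nitro in place of chloro on an aromatic carbon), and the step of a 2.8-fold higher number from compound 1 to compound 2 (0.44 log units; beyond the scatter). Compound 3 carries a different core; the difference between the core of compound 3 and the core of compound 1 is not broken down here. In this assay compound 3 gives 40 nM, the lowest number of the three and beyond the scatter from both others.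

Compound 4, `COc1cc(C(=O)c2cn(-c3cccc(N)c3)cc2-c2ccccc2[N+](=O)[O-])cc(OC)c1OC`, is the unmeasured partner of compound 3, and the change nitro in place of chloro on an aromatic carbon is the same change as that from compound 1 to compound 2, made on the same place. The step is expected to be similar, a 2.8-fold higher number from compound 3 to compound 4 (0.44 log units; beyond the scatter), because the earlier step of a 2.8-fold higher number from compound 1 to compound 2 (0.44 log units; beyond the scatter) was modest and beyond the scatter. On that basis compound 4 is estimated at 110 nM in this assay, with a range of 40 nM to 350 nM expected, since the transfer of a single step from one core to another is uncertain.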

Compound 4, half-maximal inhibitory concentration: 14 nM
Beside the measured number, compound 4's estimate is 7.9-fold (0.90 log units) above it, outside the stated range (below it).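

In this assay, nitro in place of chloro gives a 2.9-fold lower number from compound 3 to compound 4 (0.46 log units; beyond the scatter), so the direction of the change reverses between the two cores and the two steps differ: the same change on two cores in this assay, a 2.8-fold higher number (0.44 log units; beyond the scatter) from compound 1 to compound 2 and a 2.9-fold lower number (0.46 log units; beyond the scatter) from compound 3 to compound 4, 7.9-fold (0.90 log units) apart, beyond the scatter of two such steps This shows that, in this series, the step measured on the core of compound 1 cannot be carried over as a fixed increment to the core of compound 3, in either size or direction. Among the compounds shown here, it does not show which difference between the cores goes with the reversal or how the change would behave on a third core, as the comparison rests on only one pair per core in one cell assay.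

As far as these compounds go, it remains open whether a fluoro or methyl group in place of the chloro would follow the step seen on the core of compound 1 or the step seen on the core of compound 3. Also open, from the compounds shown here alone, is whether a core carrying a carboxylic acid in place of the amine would keep the order seen for compound 3 and compound 4.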